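Methyl on the pendant phenyl: expected effect on cytotoxicity

A few compounds are considered here, and "the series" means these few. Any claim that something is new, unique, unknown or untested is made for them only; others in the source may bear on it.

Compound 3 `O=C(Nc1ccc(Oc2ccnc3[nH]ccc23)c(F)c1)c1cc(-c2ccccc2)ccn1` gives 4950 nM in a functional assay on A549 cells (Homo sapiens) for cytotoxicity, read by MTT assay, with a stated time of 72 h; on this read-out higher numbers stand for weaker inhibition and lower numbers for stronger inhibition. On the three numbers in hand this is the second highest: nearest is compound 1 `Cc1cccc(-c2ccnc(C(=O)Nc3ccc(Oc4ccnc5[nH]ccc45)cc3)c2)c1`, which gives 7010 nM, and furthest is compound 2 `O=C(Nc1ccc(Oc2ccnc3[nH]ccc23)cc1)c1cc(-c2ccccc2)ccn1`, which gives 2920 nM; both of these gaps sit within the scatter, so no order among them is claimed. Compound 4 `Cc1cccc(-c2ccnc(C(=O)Nc3ccc(Oc4ccnc5[nH]ccc45)c(F)c3)c2)c1` differs from compound 3 by methyl in place of hydrogen on an aromatic carbon, placed meta to a large group; cut one bond further out, the change reads phenyl to 3-methylphenyl. Going by the values given here, the one measured step that bears directly on this exchange is a 2.4-fold lower number from compound 1 to compound 2 (0.38 log units; beyond the scatter), which is the same swap run the other way. The fluoro step a 1.7-fold higher number from compound 2 to compound 3 (0.23 log units; within the scatter) only supplies the context in which compound 4 sits and says nothing about the methyl itself. Reversing the first step, a modest rise in the number is expected for compound 4, with a 2.2-fold higher number from compound 3 to compound 4 (0.35 log units; beyond the scatter). Compound 4 is accordingly estimated at 11000 nM, within the range 5000 nM to 25000 nM.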

Compound 4, half-maximal inhibitory concentration: 1750 nM
Compound 4: the middle estimate sits 6.3-fold (0.80 log units) above what was measured, and the stated range ends above it.
By their numbers in this assay, from the lowest: compounds 4, 2, 3 and 1 (each within the scatter of the next, the first and the last beyond it).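

With the fluoro in place, methyl in place of hydrogen on the pendant phenyl gives a 2.8-fold lower number from compound 3 to compound 4 (0.45 log units; beyond the scatter) in this assay, so this change keeps no single direction across the two cores: the same change on two cores in this assay, a 2.4-fold lower number (0.38 log units; beyond the scatter) from compound 1 to compound 2 and a 2.8-fold higher number (0.45 log units; beyond the scatter) from compound 4 to compound 3, 6.8-fold (0.83 log units) apart, beyond the scatter of two such steps

The fluoro exchange depends on its setting in the same way, giving a 4.0-fold lower number from compound 1 to compound 4 (0.60 log units; beyond the scatter) with the methyl present, whereas the pair without the methyl stays within the scatter: the same change on two cores in this assay, a 1.7-fold higher number (0.23 log units; within the scatter) from compound 2 to compound 3 and a 4.0-fold lower number (0.60 log units; beyond the scatter) from compound 1 to compound 4, 6.8-fold (0.83 log units) apart, beyond the scatter of two such steps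

Across these four compounds, the methyl and the fluoro therefore do not act independently, and a step read on one core does not carry over to the other.

Going by these compounds, whether this dependence is particular to methyl stays open; a chloro, a methoxy or an amine at the same place on the phenyl, on both the fluoro and the hydrogen cores, would test it. The four compounds assign no cause to the dependence.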